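This account rests on a few compounds, and the source may have more. Where it says the series, first, only, none or still open, it means among the compounds named here.

Measured compounds:
compound 1, `O=c1[nH]c2ncc(Br)nc2n1C1CC1`, in an ADME assay on microsomes from liver (Homo sapiens), read by LC-MS, with a stated time of 90 min; a higher number here means that the liver removes a larger share of the compound in one pass, a lower number that the liver removes a smaller share: compound 1 gives "not determined" (no result reported), so no result was reported for it.
compound 2, `CCC(CC)n1c(=O)[nH]c2ncc(C(F)(F)F)nc21`, in this assay: compound 2 gives < 0.2, which is a limit of the assay and not a number.
compound 3, `C#Cc1cnc2nc(O)n(C(CC)CC)c2n1`, in this assay: compound 3 gives < 0.2, again a limit of the assay rather than a number.

Compound 2 thus stands at the low edge of what this assay can report, and it shares that position with compound 3; the two are described together by the limit of < 0.2 in this assay, at which 2 of the 3 values shown sit. Neither result pins down a single number, so the starting point for compound 2 is only known as lying at or under that limit.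

The step from compound 2 to compound 4, `CCC(CC)n1c(=O)[nH]c2ncc(C#N)nc21`, is a small one in structure: cyano in place of trifluoromethyl on an aromatic carbon. Among the compounds with values here, no measured step is available to set the size of this change in this assay, so the expectation rests on compound 2 and compound 3 alone, both of which sit at the same limit. For compound 4 a step that the limit leaves unreadable from compound 2 to compound 4 is expected, that is, none beyond the scatter. Compound 4 is therefore estimated at 0.15, with a range from 0.05 to 0.35, and it is likely that this assay again reports only a limit.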

Compound 4, hepatic extraction ratio: < 0.2
Compound 4 ended at the assay's limit (the forecaster's own chance of this, stated with the estimate: 60%); the middle value does not contradict the limit.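

In this assay, within the data shown here, compound 2 and compound 4 each give only a limit of the assay and not a number, and no step between them can be read. The compounds shown leave open how much of each compound the liver actually removes, and whether cyano in place of trifluoromethyl changes that share at all.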